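From 4-methylbenzyl to benzyl in an antiproliferative series

The source may report more compounds than this note shows. Statements on the series, on what has been measured and on what is new or still open speak of the compounds shown alone.

In a functional assay on RPMI-8226 cells (Homo sapiens) for antiproliferative activity, read by MTT assay, with a stated time of 48 h (a lower number here means a stronger inhibitor, a higher number a weaker inhibitor), compound 1 `O=C(CCC1C(=O)N(c2ccc(Cl)cc2)C(=O)N1Cc1ccc(Br)cc1)Nc1ccc(C(=O)NO)cc1` gives 360 nM and compound 2 `Cc1ccc(CN2C(=O)N(c3ccc(Cl)cc3)C(=O)C2CCC(=O)Nc2ccc(C(=O)NO)cc2)cc1` gives 230 nM. Going by the values given here, these are the only two values so far, and they lie within the scatter of each other, so compound 2 cannot be ranked apart from compound 1.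

The next compound is compound 3 `O=C(CCC1C(=O)N(c2ccc(Cl)cc2)C(=O)N1Cc1ccccc1)Nc1ccc(C(=O)NO)cc1`, which has hydrogen in place of methyl on an aromatic carbon, para to a large group: hydrogen in place of methyl on an aromatic carbon. Its 4-methylbenzyl thus becomes benzyl.

Among the compounds with values here, one measured step bears on this change, the exchange of methyl for bromo at the same carbon. That step, a 1.6-fold lower number from compound 1 to compound 2 (0.19 log units; within the scatter), stayed within the scatter. Within the data shown here, it is only a single step, and no measured compound yet carries hydrogen at this carbon, so the evidence is thin. No step beyond the scatter is therefore expected in this assay, and no direction can be firmly expected either.

The estimated step is a 1.2-fold higher number from compound 2 to compound 3 (0.09 log units; within the scatter), which is expected to remain within the scatter. For compound 3 the estimated value is 280 nM, with an expected range of 120 nM to 650 nM.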

Compound 3, half-maximal inhibitory concentration: 640 nM
Compound 3: the middle estimate sits 2.3-fold (0.36 log units) below what was measured; the measured number falls inside the stated range.
By their numbers in this assay, from the lowest: compounds 2, 1 and 3 (each within the scatter of the next, the first and the last beyond it).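

In this assay, going by these compounds alone, the change from 4-methylbenzyl to benzyl gives the first step at this aromatic carbon that lies beyond the scatter, a modest one: a 2.8-fold higher number from compound 2 to compound 3 (0.44 log units; beyond the scatter). The exchange of bromo for hydrogen at the same carbon, a 1.8-fold higher number from compound 1 to compound 3 (0.25 log units; within the scatter), stays within the scatter, so among these three groups only methyl and hydrogen stand apart, and bromo cannot be separated from either. The position is therefore not wholly indifferent to what it carries, but nothing available gives a reason for the gap between methyl and hydrogen.

With only hydrogen, methyl and bromo at this carbon, the compounds shown cannot tell whether the separation from hydrogen is particular to methyl or would also appear with an ethyl, a methoxy or an amino group in its place. They also leave open whether the same step would recur if the 4-chlorophenyl group on the shared core carried something else, such as a plain phenyl or a 4-methoxyphenyl group.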